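Cyclopentyl in Place of Isobutyl on the Amide Carbonyl

The source may hold more compounds than are shown below. What is called first, only, known or untested is meant among the compounds shown, and "the series" means these compounds.

In an assay on CHO cells for displacement of a labelled ligand from adenosine receptor A1 (Homo sapiens), read by scintillation counting, with a stated time of 1 h, tested at 1 uM (on this read-out lower numbers stand for less inhibition and higher numbers for more inhibition at the one concentration tested (going by the name of the read-out)), compound 1 `CCCC(=O)Nc1ncc(-c2cccc(Cl)c2)c(-c2ccccc2)n1` gives > 80%, which is a limit of the assay rather than a number. Compound 2 `CCCCC(=O)Nc1ncc(-c2cccc(Cl)c2)c(-c2ccccc2)n1` gives 52% in this assay, and compound 3 `CC(C)CC(=O)Nc1ncc(-c2cccc(Cl)c2)c(-c2ccccc2)n1` gives 56%. Compound 3 thus holds the higher of the two numbers, with compound 2 nearest and within the scatter of it, while the third value is a limit. The step of a number at least 24 percentage points lower from compound 1 to compound 3 (beyond the scatter) and the step of a number at least 28 percentage points lower from compound 1 to compound 2 (beyond the scatter) both show that adding a carbon to the acyl chain lowers inhibition, whereas the step of a number 4 percentage points higher from compound 2 to compound 3 (within the scatter) is within the scatter. Compound 4 `O=C(Nc1ncc(-c2cccc(Cl)c2)c(-c2ccccc2)n1)C1CCCC1` differs from compound 3 by cyclopentyl in place of isobutyl on a carbonyl carbon. This enlarges the acyl group further, so a modest further fall is expected, though the comparison of compound 2 with compound 3 suggests the shape of the group matters little, and compound 4 is estimated at 48% in this assay, between 25% and 72%, a step of a number 8 percentage points lower from compound 3 to compound 4 (within the scatter).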

Compound 4, a percentage reported as inhibition, at one concentration (the size of the read-out at that concentration, not a potency): 47%
For compound 4 the middle estimate is 1 percentage points above the measured one; low and high end bracket the measured number.
By their numbers in this assay, from the lowest: compounds 4, 2 and 3 (each within the scatter of the next). At a limit, above all of these: compound 1.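

In this assay, the ring on this carbonyl carbon cannot be told apart from the open chains, with a number 9 percentage points lower from compound 3 to compound 4 (within the scatter) and a number 5 percentage points lower from compound 2 to compound 4 (within the scatter), so cyclopentyl sits level with isobutyl and butyl. Against the propyl group the picture is different, with a number at least 33 percentage points lower from compound 1 to compound 4 (beyond the scatter), which places cyclopentyl with the other larger groups on the far side of that gap, whether the group is branched, straight or closed into a ring. Compound 1 stands at a limit, not at a number: the limit of > 80% in this assay, at which 1 of the 4 values shown sits.

As far as these compounds go, what a cyclopropyl or an acetyl group would give in place of cyclopentyl stays open, and so does the effect of a ring carrying an amine, such as piperidine. From the compounds shown here alone, how compounds 2, 3 and 4 compare in potency also stays open, as a reading at one concentration does not give it.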